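This account rests on a few compounds, and the source may have more. Where it says the series, first, only, none or still open, it means among the compounds named here.

Measured so far:
- compound 1, `CCOc1ncc(-c2nc(C(F)(F)F)sc2N2CCN(C(=O)Cn3ncc4cccnc43)[C@H](C)C2)cn1`, in a functional assay on U2OS cells for antagonist activity at C-X-C chemokine receptor type 3 (Homo sapiens), read by beta-arrestin recruitment (a lower number here means a stronger inhibitor, a higher number a weaker inhibitor), compound 1 gives 55 nM
- compound 2, `CCOc1ncc(-c2nc(C(F)(F)F)sc2N2CCN(C(=O)Cn3cnc(C(F)(F)F)n3)[C@H](C)C2)cn1`, in this assay compound 2 gives 118 nM

Going by the values given here, compound 2 stands as the weaker of the two measured compounds, with the higher number of the pair: the one step connecting them, a 2.1-fold higher number from compound 1 to compound 2 (0.33 log units; beyond the scatter), put compound 2 behind compound 1 by a margin beyond the scatter, though a modest one.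

Compound 3, `CCOc1ncc(-c2nc(C(F)(F)F)sc2N2CCN(C(=O)Cn3cc(Cl)cn3)[C@H](C)C2)cn1`, has not yet been measured. Its change from compound 2 is 4-chloro-1H-pyrazol-1-yl in place of 3-(trifluoromethyl)-1H-1,2,4-triazol-1-yl on a saturated chain carbon bound to a carbonyl carbon. Among the compounds with values here, the only measured step that bears on this position is the same exchange of a five-membered aromatic group on the saturated chain carbon bound to the carbonyl carbon, a 2.1-fold higher number from compound 1 to compound 2 (0.33 log units; beyond the scatter), which shows that this part of the molecule can shift the number by a modest amount in either direction. Within the data shown here, with just one such step in hand, and no measured compound carrying a halogen on that ring, the direction for compound 3 cannot be read off with confidence; a change roughly within the scatter, perhaps leaning to a slightly lower number, is the expectation. For compound 3 the expected step is a 1.3-fold lower number from compound 2 to compound 3 (0.12 log units; within the scatter). Compound 3 is therefore estimated at 90 nM, with a range from 35 nM to 250 nM.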

Compound 3, half-maximal inhibitory concentration: 272 nM
Estimate against measurement, compound 3: 3.0-fold (0.48 log units) below; measured number above the stated range.
By their numbers in this assay, from the lowest: compound 1; then compound 2; then compound 3.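

In this assay, putting 4-chloro-1H-pyrazol-1-yl in place of 3-(trifluoromethyl)-1H-1,2,4-triazol-1-yl on the saturated chain carbon bound to a carbonyl carbon gives a 2.3-fold higher number from compound 2 to compound 3 (0.36 log units; beyond the scatter), so a second exchange at this position also moves the number beyond the scatter, and again upward. Over the three compounds the position proves more sensitive than the first step alone could show, with a 4.9-fold higher number from compound 1 to compound 3 (0.69 log units; beyond the scatter), and the group of compound 1, which carries a six-membered aromatic ring as well as a five-membered one, keeps the lowest number while both groups with only a five-membered ring stand above it. Nothing measured here explains this order.

On these data alone, two things changed at once from compound 2 to compound 3, the ring and its substituent, so it remains open whether a plain 1H-pyrazol-1-yl group would sit nearer compound 2 or compound 3. As far as these compounds go, it is also open how this position would respond to a group of another kind on the ring, such as a methoxy group, a nitrile or an amine.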